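This account rests on a few compounds, and the source may have more. Where it says the series, first, only, none or still open, it means among the compounds named here.

Compound 1 `C[C@H]1O[C@@H](n2cc(F)c(NC(=O)Oc3ccc(Cl)cc3)nc2=O)[C@H](O)[C@@H]1O` gives 30 ug/mL
Compound 2 `CCCCCOC(=O)Nc1nc(=O)n([C@@H]2O[C@H](C)[C@H]3OC(=O)O[C@H]32)cc1F` gives 80 ug/mL

In a functional assay on HeLa cells (Homo sapiens) for cytotoxicity, read by MTT assay, with a stated time of 3 days (on this read-out higher numbers stand for weaker inhibition and lower numbers for stronger inhibition), compound 2 gives 80 ug/mL as the higher of the two numbers, a gap from compound 1 that lies beyond the scatter. Compound 3 `C[C@H]1O[C@@H](n2cc(F)c(NC(=O)Oc3ccc([N+](=O)[O-])cc3)nc2=O)[C@@H]2OC(=O)O[C@@H]21` differs from compound 2 4-nitrophenyl in place of pentyl on an oxygen next to a carbonyl group with 4-nitrophenyl in place of pentyl on an oxygen next to a carbonyl group. Within the data shown here, no measured pair isolates this change. Compound 1, which also has an aromatic ring on that oxygen, gives 30 ug/mL and so a moderate step to a lower number is expected in this assay. The expected step (a 2.3-fold lower number from compound 2 to compound 3 (0.36 log units; beyond the scatter)) remains uncertain. Compound 3 is estimated at 35 ug/mL (range 10 ug/mL to 110 ug/mL).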

Compound 3, half-maximal inhibitory concentration: 30 ug/mL
Compound 3: the middle estimate sits 1.2-fold (0.07 log units) above what was measured, within the range that was stated.
By their numbers in this assay, from the lowest: compounds 1 and 3 (each within the scatter of the next); then compound 2.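

In this assay, among these compounds, the change from pentyl to 4-nitrophenyl on an oxygen next to a carbonyl group gives a 2.7-fold lower number from compound 2 to compound 3 (0.43 log units; beyond the scatter) and is the first reading of this position with everything else held constant. The step is modest, yet it shows that the number at this position responds to the group placed there. Nothing at hand accounts for the step. Going by these compounds, whether the ring alone or its nitro substituent carries the step stays open, as does how an unsubstituted phenyl or a longer chain on that oxygen would read.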